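This account rests on a few compounds, and the source may have more. Where it says the series, first, only, none or still open, it means among the compounds named here.

Measured compounds in an ADME assay on Vero cells (Chlorocebus sabaeus) for cytotoxicity, read by MTT assay, with a stated time of 72 h; on this read-out higher numbers stand for lower toxicity in this test and lower numbers for higher toxicity in this test:

- compound 1, `C[C@]1(CN2CCc3sc(-c4ccc(F)cc4)nc3C2)Cn2cc([N+](=O)[O-])nc2O1`: "not determined" (no result reported)
- compound 2, `C[C@]1(CN2CCc3nc(-c4ccc(F)cc4)sc3C2)Cn2cc([N+](=O)[O-])nc2O1`: > 32 ug/mL (a limit of the assay, not a number)
- compound 3, `C[C@]1(CN2CCc3nc(-c4cccc(F)c4)ccc3C2)Cn2cc([N+](=O)[O-])nc2O1`: > 32 ug/mL (a limit of the assay, not a number)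

Compound 3 stands at the limit rather than at a measured number in this assay. Compound 2 sits at the same limit in its own right. Compound 1 carries no result here. So within this set nothing separates compound 3 from compound 2, and no measured step between compounds exists to calibrate the size of a structural change; the only fixed point is the limit of > 32 ug/mL in this assay, at which 2 of the 3 values shown sit.

Compound 4, `C[C@]1(CN2CCc3nc(-c4cccc(Cl)c4F)ccc3C2)Cn2cc([N+](=O)[O-])nc2O1`, is to be measured in this assay. Its difference from compound 3: 3-chloro-2-fluorophenyl in place of 3-fluorophenyl on an aromatic carbon. Going by the values given here, no comparable step among the measured compounds is available, so the expected step is set by the position of compound 3 alone: the estimate is a step of a number no higher from compound 3 to compound 4 (the limit leaves the size open), small and not beyond the usual scatter, with the outcome most likely again a limit rather than a number.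

Compound 4 is thus expected to give about 32 ug/mL in this assay, in the range 12 ug/mL to 64 ug/mL.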

Compound 4, half-maximal cytotoxic concentration: > 32 ug/mL
Compound 4: only a limit was reported (the forecaster's own chance of this, stated with the estimate: 65%); the middle value sits exactly at the limit.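

In this assay, going by these compounds alone, compound 3 and compound 4 both rest at a limit of the assay, not a number, and no step between them can be read. The compounds shown leave open whether 3-chloro-2-fluorophenyl and 3-fluorophenyl differ at all in this assay, and where any of these compounds would give a number, the only fixed point being this: the limit of > 32 ug/mL in this assay, at which 3 of the 4 values shown sit.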